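Swapping a Pyridine Amide for a Chlorophenyl Amide

The source may hold more compounds than are shown below. What is called first, only, known or untested is meant among the compounds shown, and "the series" means these compounds.

Compound 1 `CCN1CCN(c2cc(C)c3cc(NC(=O)c4cccnc4)ccc3n2)CC1` carries a pyridin-3-yl group on its amide carbonyl and, in a functional assay on MCF7 cells (Homo sapiens) for antiproliferative activity, read by MTT assay, with a stated time of 72 h (a higher number here means a weaker inhibitor, a lower number a stronger inhibitor), compound 1 gives 26600 nM. Of the two compounds measured, compound 1 has the highest number, so it is the weaker inhibitor of the pair. Compound 2 `Cc1cc(N2CCN(C(C)C)CC2)nc2ccc(NC(=O)c3ccc(Cl)c(Cl)c3)cc12`, which has a dichlorophenyl amide and a different group on its piperazine nitrogen, gives 1710 nM in this assay. Compound 3 `CCN1CCN(c2cc(C)c3cc(NC(=O)c4ccccc4Cl)ccc3n2)CC1` keeps the core of compound 1 and differs from it at one spot: 2-chlorophenyl in place of pyridin-3-yl on a carbonyl carbon. For the measured compounds named here, no direct pair that isolates this change has been measured, so the expectation rests on the gap between compound 1 and compound 2 and on the change itself. Compound 3 is expected to be the stronger inhibitor, with a step of a 4.4-fold lower number from compound 1 to compound 3 (0.65 log units; beyond the scatter), beyond the usual scatter. Compound 3 is estimated at 6000 nM, within a range from 2000 nM to 18000 nM.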

Compound 3, half-maximal inhibitory concentration: > 50000 nM
Compound 3 gave a limit, no number (the forecaster's own chance of this, stated with the estimate: 5%); at least 8.3-fold (0.92 log units) between middle value and limit.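

On this carbonyl carbon, 2-chlorophenyl in place of pyridin-3-yl brings no lower number in this assay, and the step reads an at least 1.8-fold higher number from compound 1 to compound 3 (0.27 log units; that floor lies within the scatter). A phenyl ring carrying a chlorine at this place is therefore not enough on its own to give a stronger inhibitor on the core of compound 1, something the earlier pair, which differs in more than one place, could not show. For compound 3 the result is a limit and not a number, so the full size of the step stays unknown because the only reading is this: the limit of > 50000 nM in this assay, at which 1 of the 3 values shown sits.

Still open, as far as these compounds go, is how a plain phenyl group without chlorine, or a methoxyphenyl group, would read on this carbonyl carbon. Also open, from the compounds shown here alone, is how a dichlorophenyl amide would read on the core of compound 1 with its ethyl group kept on the piperazine nitrogen.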